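A few compounds are considered here, and "the series" means these few. Any claim that something is new, unique, unknown or untested is made for them only; others in the source may bear on it.

In a functional assay on HCT-116 cells (Homo sapiens) for antiproliferative activity, read by MTT assay, with a stated time of 72 h (on this read-out higher numbers stand for weaker inhibition and lower numbers for stronger inhibition), compound 1 `CC(C)(C)[C@H](NC(=O)N1C/C(=C\c2ccc(F)cc2)C(=O)/C(=C/c2ccc(F)cc2)C1)B1OC(C)(C)C(C)(C)O1` gives 828 nM, compound 2 `CC1(C)OB([C@@H](NC(=O)N2C/C(=C\c3ccc(F)cc3)C(=O)/C(=C/c3ccc(F)cc3)C2)C2CCCCC2)OC1(C)C` gives 903 nM and compound 3 `CC(C)C[C@H](NC(=O)N1C/C(=C\c2ccc(F)cc2)C(=O)/C(=C/c2ccc(F)cc2)C1)B1OC(C)(C)C(C)(C)O1` gives 824 nM, so compound 3 stands level with the other two, within the scatter. Compound 4 `CC[C@H](NC(=O)N1C/C(=C\c2ccc(F)cc2)C(=O)/C(=C/c2ccc(F)cc2)C1)B1OC(C)(C)C(C)(C)O1` differs from compound 3 by methyl in place of isopropyl on a saturated chain carbon, two bonds along the chain from an amide-type nitrogen and a boron atom, with methyl in place of isopropyl on a saturated chain carbon, two bonds along the chain from an amide-type nitrogen and a boron atom. The measured steps that bear on this change, a 1.0-fold lower number from compound 1 to compound 3 (0.00 log units; within the scatter), a 1.1-fold lower number from compound 2 to compound 3 (0.04 log units; within the scatter) and a 1.1-fold higher number from compound 1 to compound 2 (0.04 log units; within the scatter), all lie within the scatter, although none of them puts ethyl at that place. No change beyond the scatter is therefore expected in this assay, and the estimated step is a 1.0-fold higher number from compound 3 to compound 4 (0.01 log units; within the scatter). The expected value for compound 4 is 850 nM, within an estimated range of 500 nM to 1500 nM.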

Compound 4, half-maximal inhibitory concentration: 876 nM
Compound 4: middle estimate off by 1.0-fold (0.01 log units), on the low side; low and high end bracket the measured number.
By their numbers in this assay, from the lowest: compounds 3, 1, 4 and 2 (each within the scatter of the next).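

In this assay the ethyl of compound 4 stands level with the isobutyl of compound 3 (a 1.1-fold higher number from compound 3 to compound 4 (0.03 log units; within the scatter)), the cyclohexyl of compound 2 (a 1.0-fold lower number from compound 2 to compound 4 (0.01 log units; within the scatter)) and the tert-butyl of compound 1 (a 1.1-fold higher number from compound 1 to compound 4 (0.02 log units; within the scatter)). Within the data shown here, the earlier compounds showed only that these three groups could replace one another, whereas this result shows that the chain can be cut back from isobutyl to ethyl with no change beyond the scatter. No measurement is available that would explain this flat result.

The compounds shown leave open whether an amine, a carboxylic acid or a phenyl ring at this place would stay at the same level.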